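Compound 3 and the loss of 2-phenylethenyl

A few compounds are considered here, and "the series" means these few. Any claim that something is new, unique, unknown or untested is made for them only; others in the source may bear on it.

Among the measured compounds shown here, compound 3 `COc1ccc(Nc2cc(/C=C/c3ccccc3)oc(=O)c2)cc1` gives 0.15 uM in a functional assay on KB cells (Homo sapiens) for cytotoxicity, read by MTT assay, with a stated time of 72 h (a higher number here means that more compound is needed for the effect, a lower number that less compound is needed), as the lowest number so far. Compound 1 `O=c1cc(NC2CCCCC2)cc(/C=C/c2ccccc2)o1` is the nearest number at 2.02 uM for comparison. Compound 2 `COc1ccc(Nc2cc(C)oc(=O)c2)cc1` stands at > 30 uM as a limit and not a number.

Compound 4 `COc1ccc(Nc2cc(C(C)C)oc(=O)c2)cc1` has isopropyl in place of 2-phenylethenyl on an aromatic carbon. The closest measured step is the one between methyl and 2-phenylethenyl at this same place (an at least 200-fold lower number from compound 2 to compound 3 (2.30 log units; beyond the scatter)). The other step (a 13-fold lower number from compound 1 to compound 3 (1.13 log units; beyond the scatter)) lies at the nitrogen and bears on this change only indirectly. Isopropyl, with no ring, is nearer to methyl than to 2-phenylethenyl, so in this assay a large rise is expected, possibly reaching a limit. The expected size is large (a 130-fold higher number from compound 3 to compound 4 (2.12 log units; beyond the scatter)). Compound 4 is estimated at 20 uM (5 uM to 60 uM).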

Compound 4, concentration for half-maximal effect: > 30 uM
Compound 4 was reported as a limit; the forecaster's own chance of this, stated with the estimate: 55%; at least 1.5-fold (0.17 log units) between middle value and limit.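

On the aromatic carbon next to the ring oxygen, isopropyl in place of 2-phenylethenyl gives an at least 200-fold higher number from compound 3 to compound 4 (2.30 log units; beyond the scatter) in this assay, so the loss seen with methyl also appears with a second group that has no ring. Compound 4 is reported only as a limit. The step from compound 2 to compound 4 cannot be read, and the two groups stay unranked at this place: the limit of > 30 uM in this assay, at which 2 of the 4 values shown sit.

Open, from the compounds shown here alone, is whether the ring or the double bond of 2-phenylethenyl matters more, which phenyl or 2-phenylethyl here would help separate. An amine or a longer chain at this carbon also remains unplaced.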